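Replacing 4-nitrophenyl with 3-chlorophenyl on compound 2

The compounds below may be only part of what the source reports. "The series", "measured", "known", "first", "only" and "open" are said of these compounds alone.

Measured so far in a functional assay on MCF7 cells (Homo sapiens) for inhibition, read by MTT assay, with a stated time of 48 h, tested at 10 uM; a lower number here means less inhibition of growth, a higher number more inhibition of growth at the concentration tested:
- Compound 1 `Cc1cc(=O)c2c(O)c(CN3CCC(N4CCCCC4)CC3)c(O)c([C@H]3CCN(C)C[C@H]3O)c2o1`: 25%
- Compound 2 `Cc1oc2c([C@H]3CCN(C)C[C@H]3O)c(O)cc(O)c2c(=O)c1C(O)c1ccc([N+](=O)[O-])cc1`: 4%

Of these two compounds, compound 2 stands lowest at 4%. Its nearest neighbour, compound 1, reads 25%, and that gap lies beyond the usual scatter. Among the compounds with values here, the two differ in more than one place, so the pair gives no measured step for a single change.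

The next compound to be tested is compound 3 `Cc1oc2c([C@H]3CCN(C)C[C@H]3O)c(O)cc(O)c2c(=O)c1C(O)c1cccc(Cl)c1`. It carries 3-chlorophenyl in place of 4-nitrophenyl on a saturated chain carbon bound to an aromatic carbon and an oxygen on a saturated carbon. The rest of the structure stays as it is in compound 2.

Within the data shown here, no measured pair shows what this exchange does in this assay, so the expectation rests on compound 2 at 4%. A step within the scatter is expected, with a slight lean upward, and the estimated change is a number 5 percentage points higher from compound 2 to compound 3 (within the scatter). For compound 3 the estimated value is 9%, with an expected range of 0% to 22%.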

Compound 3, percent growth inhibition at one concentration: 5%
The estimate for compound 3 lay 4 percentage points above the measured number; low and high end bracket the measured number.
By their numbers in this assay, from the lowest: compounds 2 and 3 (each within the scatter of the next); then compound 1.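

In this assay, within the data shown here, the exchange of 4-nitrophenyl for 3-chlorophenyl on a saturated chain carbon bound to an aromatic carbon and an oxygen on a saturated carbon gave a number 1 percentage points higher from compound 2 to compound 3 (within the scatter), the first measured single-place step. This assay therefore does not separate these two aryl groups at this position, with compound 2 at 4% and compound 3 at 5%, even though the exchange removes the nitrogen and oxygen atoms of the 4-nitrophenyl group and brings in a chlorine atom. No supporting measurement is available to explain why the two readings stay so close.

With only these two aryl groups shown at this carbon, it remains open whether an unsubstituted phenyl ring, a phenyl ring bearing a carboxylic acid or an amine, or a saturated ring in the same place would read differently. Also open, on these data alone, is what the hydroxy group on this carbon contributes, and whether the same exchange would matter in a compound that reads differently from these two.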